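The compounds below may be only part of what the source reports. "The series", "measured", "known", "first", "only" and "open" are said of these compounds alone.

Measured so far, in a functional assay on isolated protein for inhibition of Glucose-dependent insulinotropic receptor (Rattus norvegicus), read by HTRF and cAMP accumulation; a higher number here means a larger maximal response, a lower number a smaller maximal response:

Compound 1 `Cc1nc(S(C)(=O)=O)ccc1Oc1ncnc(OC2CCN(C(=O)O[C@H](C)CF)CC2)c1F` gives 79%.
Compound 2 `Cc1nc(S(C)(=O)=O)ccc1Oc1ncnc(OC2CCN(C(=O)C(C)(C)F)CC2)c1F` gives 74%.
Compound 3 `Cc1nc(S(C)(=O)=O)ccc1Oc1ncnc(OC2CCN(C(=O)C3CCCC3)CC2)c1F` gives 83%.

All three compounds share one core and differ only in the group on the carbonyl carbon attached to the ring nitrogen. Compound 3 shows the largest of the three numbers, yet none of the three stands apart from the others: a number 5 percentage points lower from compound 1 to compound 2 (within the scatter), a number 4 percentage points higher from compound 1 to compound 3 (within the scatter) and a number 9 percentage points higher from compound 2 to compound 3 (within the scatter) all lie within the scatter of repeated measurements. So far, exchanging one small group for another at this position has not moved the maximal response beyond the noise.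

Compound 4 `Cc1nc(S(C)(=O)=O)ccc1Oc1ncnc(OC2CCN(C(=O)c3ncc(Cl)cn3)CC2)c1F` continues this series at the same position. 5-chloropyrimidin-2-yl in place of cyclopentyl on a carbonyl carbon

Every measured step bears on this change, since each replaces the group on the carbonyl carbon, and each was within the scatter. On that basis no step beyond the scatter is expected for a number 3 percentage points lower from compound 3 to compound 4 (within the scatter). Compound 4 is therefore estimated at 80%, with a range from 65% to 92%.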

Compound 4, largest response reached (reported as efficacy), in percent of the reference or control that the assay uses: 77%
For compound 4 the middle estimate is 3 percentage points above the measured one; low and high end bracket the measured number.
By their numbers in this assay, from the lowest: compounds 2, 4, 1 and 3 (each within the scatter of the next).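

In this assay, going by these compounds alone, the group on the carbonyl carbon can now be an aromatic ring: 5-chloropyrimidin-2-yl, with its ring nitrogens and chlorine, replaces the non-aromatic groups of the earlier compounds without a step beyond the scatter. This holds against all three comparators, with a number 6 percentage points lower from compound 3 to compound 4 (within the scatter), a number 3 percentage points higher from compound 2 to compound 4 (within the scatter) and a number 2 percentage points lower from compound 1 to compound 4 (within the scatter). No measurement shown accounts for this level response across such different groups.

The compounds shown leave open whether an amine, a carboxylic acid or a longer alkyl chain on this carbonyl carbon would move the maximal response beyond the scatter. Equally open, on these data alone, is what a pyrimidin-2-yl group without the chlorine, or a plain phenyl ring, would give in this assay.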